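Hydroxy for amino on the amide side chain

The source may hold more compounds than are shown below. What is called first, only, known or untested is meant among the compounds shown, and "the series" means these compounds.

Measured in an assay on HEK293 cells for displacement of a labelled ligand from NPC1-like intracellular cholesterol transporter 1 (Homo sapiens); on this read-out higher numbers stand for weaker inhibition and lower numbers for stronger inhibition:
Compound 1 `CC(C)(C)c1ccc(C(=O)N2CCC3(CC2)C(=O)N(CC(=O)NCCO)CN3c2ccccc2)cc1` gives 1000 nM.
Compound 2 `CC(C)(C)c1ccc(C(=O)N2CCC3(CC2)C(=O)N(CC(=O)NCN)CN3c2ccccc2)cc1` gives 26500 nM.
Compound 3 `CC(C)(C)c1ccc(C(=O)N2CCC3(CC2)C(=O)N(CC(=O)NCCCCN)CN3c2ccccc2)cc1` gives 14500 nM.

The three share one core and differ only in the chain on the amide-type nitrogen. The change hydroxymethyl in place of amino on a saturated chain carbon bound to an amide-type nitrogen gave a 27-fold lower number from compound 2 to compound 1 (1.42 log units; beyond the scatter). Compounds 2 and 3 differ by 3-aminopropyl in place of amino on a saturated chain carbon bound to an amide-type nitrogen, with a 1.8-fold lower number from compound 2 to compound 3 (0.26 log units; within the scatter); compound 1 against compound 3 shows a 15-fold higher number from compound 1 to compound 3 (1.16 log units; beyond the scatter).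

Compound 4 `CC(C)(C)c1ccc(C(=O)N2CCC3(CC2)C(=O)N(CC(=O)NCCCCCO)CN3c2ccccc2)cc1` differs from compound 3 by hydroxymethyl in place of amino on a saturated chain carbon, four bonds along the chain from an amide-type nitrogen. This is the same kind of change as from compound 2 to compound 1, but not the same: there the place was on a saturated chain carbon bound to an amide-type nitrogen, here it is four bonds along the chain from that nitrogen. A step in the same direction is expected for compound 4, but smaller than a 27-fold lower number from compound 2 to compound 1 (1.42 log units; beyond the scatter), because the large gain stood on the shortest chain and compound 3 shows 14500 nM on a long one. Compound 4 is therefore expected at 3500 nM, a step of a 4.1-fold lower number from compound 3 to compound 4 (0.62 log units; beyond the scatter), within 800 nM to 15000 nM.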

Compound 4, half-maximal inhibitory concentration: 9400 nM
Beside the measured number, compound 4's estimate is 2.7-fold (0.43 log units) below it; the range from low to high includes it.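

Carried to the longer chain, the change from amino to hydroxymethyl did not keep its size in this assay: the same change on two cores in this assay, a 27-fold lower number (1.42 log units; beyond the scatter) from compound 2 to compound 1 and a 1.5-fold lower number (0.19 log units; within the scatter) from compound 3 to compound 4, 17-fold (1.24 log units) apart, beyond the scatter of two such steps. On that chain the step is a 1.5-fold lower number from compound 3 to compound 4 (0.19 log units; within the scatter), while the other new steps are a 2.8-fold lower number from compound 2 to compound 4 (0.45 log units; beyond the scatter) and a 9.4-fold higher number from compound 1 to compound 4 (0.97 log units; beyond the scatter), so the hydroxy chain of compound 1 keeps the lowest number of the series. Going by these compounds alone, this shows that the gain seen on the shortest chain cannot be assumed on a longer one, but with only two such pairs it does not show how the step varies with chain length, nor why it shrinks. Still open, on these data alone, is how amine and alcohol chains of intermediate length would behave, and whether a carboxylic acid at the chain end would match the hydroxy chain of compound 1.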